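Shortening the Side Chain in a Weakly Inhibiting Series

The source may report more compounds than this note shows. Statements on the series, on what has been measured and on what is new or still open speak of the compounds shown alone.

Compound 1, `CC[C@@H](c1nc2ccc(C(=O)O)cc2n1C)N1C(=O)CN(c2ccc(Oc3ccccc3)cc2)C1=O`, gives 210000 nM in an assay on isolated protein for inhibition of Bile acid receptor (Homo sapiens), read by TR-FRET and LanthaScreen; on this read-out lower numbers stand for stronger inhibition and higher numbers for weaker inhibition.
Compound 2, `Cc1ccc2nc([C@H](CC3CCCCC3)N3C(=O)CN(c4ccc(Oc5ccccc5)cc4)C3=O)n(C)c2c1`, gives 126000 nM in this assay.
Compound 3, `CC(C)C[C@@H](c1nc2ccc(C(=O)O)cc2n1C)N1C(=O)CN(c2ccc(F)cc2)C1=O`, gives 399000 nM in this assay.

All three measured compounds inhibit only weakly in this assay. Compound 1 has the second highest of the three numbers, but its gap to compound 2, the nearest, and its gap to compound 3, the furthest, both lie within the usual scatter of repeated measurements, so no order among the three can be claimed from these numbers alone.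

Compound 4, `C[C@@H](c1nc2ccc(C(=O)O)cc2n1C)N1C(=O)CN(c2ccc(Oc3ccccc3)cc2)C1=O`, has not yet been measured. It differs from compound 1 in one place: hydrogen in place of methyl on a saturated chain carbon, two bonds along the chain from an amide-type nitrogen in a ring and an aromatic carbon. The shared core, the acid on it, and the ring-bearing group on the far side of the central ring are unchanged.

Within the data shown here, with no comparable step between measured compounds available, the size of this change can only be judged as small. The step from compound 1 to compound 4 in this assay is expected to stay within the scatter, in no clear direction. Compound 4 is estimated at 250000 nM, with a likely range from 100000 nM to 600000 nM, which corresponds to an expected 1.2-fold higher number from compound 1 to compound 4 (0.08 log units; within the scatter).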

Compound 4, half-maximal inhibitory concentration: 10400 nM
For compound 4 the middle estimate is 24-fold (1.38 log units) above the measured one, and the stated range ends above it.
By their numbers in this assay, from the lowest: compound 4; then compounds 2, 1 and 3 (each within the scatter of the next, the first and the last beyond it).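

In this assay, among these compounds, the change from ethyl to methyl on this saturated chain carbon gives a 20-fold lower number from compound 1 to compound 4 (1.31 log units; beyond the scatter) and is the first single-place step, showing that this one position can move the number well beyond the scatter. The change itself is slight: one carbon leaves, and no ring, hydrogen-bond donor, hydrogen-bond acceptor or net charge leaves or enters, while the shared core, the acid on it and the ring-bearing group on the far side of the central ring stay the same. Nothing measured here explains why so slight a change is followed by so large a step.

The compounds shown leave open whether the number keeps falling when hydrogen replaces the remaining methyl on this carbon, and how a cyclopropyl or hydroxymethyl group would read there, as well as the mirror-image arrangement at the same carbon. They also leave open whether the ethyl to methyl step keeps its size when the carboxylic acid on the shared core gives way to a primary amide or a tetrazole.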